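The source may report more compounds than this note shows. Statements on the series, on what has been measured and on what is new or still open speak of the compounds shown alone.

In a toxicity assay on GES1 cells (Homo sapiens) for inhibition, read by MTT assay, with a stated time of 72 h; a higher number here means a weaker inhibitor, a lower number a stronger inhibitor:
Compound 1 `Cc1cc(N2CC[C@@H](C)[C@@H](N(C)c3ncnc4[nH]ccc34)C2)n2ncnc2n1`: 57900 nM
Compound 2 `C=CCSc1nc2nc(C)cc(N3CC[C@@H](C)[C@@H](N(C)c4ncnc5[nH]ccc45)C3)n2n1`: > 100000 nM (a limit of the assay, not a number)

Compound 2 sits at the limit of > 100000 nM in this assay, at which 1 of the 2 values shown sits, so only one side of its position is known. Compound 3 `Cc1cc(N2CC[C@@H](C)[C@@H](N(C)c3ncnc4[nH]ccc34)C2)n2nc(SCc3ccc(C(F)(F)F)cc3)nc2n1` keeps the sulfur and changes the group on it: 4-(trifluoromethyl)phenyl in place of vinyl on a saturated chain carbon bound to a sulfur. Cut one bond further out, allylsulfanyl gives way to (4-(trifluoromethyl)benzyl)sulfanyl. Going by the values given here, the only measured step bearing on this is an at least 1.7-fold higher number from compound 1 to compound 2 (0.23 log units; that floor lies within the scatter), which concerns allylsulfanyl in place of hydrogen on an aromatic carbon. Among the compounds with values here, no measured step covers the 4-(trifluoromethyl)phenyl itself, so no step beyond the scatter is expected in this assay, and no direction is firmly expected. Compound 3 is expected at 80000 nM, with an estimated range of 25000 nM to 150000 nM. The estimate means an at least 1.2-fold lower number from compound 2 to compound 3 (0.09 log units; that floor lies within the scatter).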

Compound 3, half-maximal inhibitory concentration: 17300 nM
Compound 3: the middle estimate sits 4.6-fold (0.67 log units) above what was measured, outside the stated range (below it).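

In this assay, the group on the sulfur matters: exchanging the vinyl for 4-(trifluoromethyl)phenyl on the saturated chain carbon bound to the sulfur gives an at least 5.7-fold lower number from compound 2 to compound 3 (0.76 log units; beyond the scatter). Going by these compounds alone, compound 2 carries a limit of the assay, so that step is a floor and its true size stays unknown: the limit of > 100000 nM in this assay, at which 1 of the 3 values shown sits. Measured against the hydrogen of the core, (4-(trifluoromethyl)benzyl)sulfanyl gives a 3.3-fold lower number from compound 1 to compound 3 (0.52 log units; beyond the scatter), the first step at this aromatic carbon that lies beyond the scatter, and it shows that a group here can bring the number down.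

As far as these compounds go, whether the lower number goes with the aromatic ring or with the trifluoromethyl stays open. Also open, from the compounds shown here alone, is how a plain benzylsulfanyl, a longer alkylsulfanyl chain or a sulfanyl chain ending in an amine would read in this assay.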